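Moving the bromine on the anilino ring

A few compounds are considered here, and "the series" means these few. Any claim that something is new, unique, unknown or untested is made for them only; others in the source may bear on it.

Compound 1, `Fc1cccc(Nc2nc(-c3cccc(F)c3)nc3ccc(F)cc23)c1`, in a functional assay on HL-60 cells (Homo sapiens) for cytotoxicity, read by MTT assay, with a stated time of 48 h (on this read-out lower numbers stand for stronger inhibition and higher numbers for weaker inhibition), gives 43100 nM.
Compound 2, `Fc1cccc(-c2nc(Nc3ccc(Br)cc3)c3cc(F)ccc3n2)c1`, in this assay gives > 50000 nM.

The figure for compound 2 is a limit of the assay rather than a measured number; of the two values shown, one sits at the limit of > 50000 nM in this assay, at which 1 of the 2 values shown sits. Among the measured compounds shown here, compound 1 is the only other compound measured, and the step of an at least 1.1-fold higher number from compound 1 to compound 2 (0.06 log units; that floor lies within the scatter) changed the whole ring on that nitrogen, with a floor that lies within the usual scatter. Compound 3, `Fc1cccc(-c2nc(Nc3cccc(Br)c3)c3cc(F)ccc3n2)c1`, differs from compound 2 only in where the bromine sits: 3-bromophenyl in place of 4-bromophenyl on a nitrogen on an aromatic ring. No measured step moves a bromine from one place to another on that ring, so nothing shown bears directly on this change. For the measured compounds named here, both measured compounds sit at or near the weak end of the scale, and the one step that exists is small. Compound 3 is therefore expected to stay near compound 2, with the step that the limit leaves unreadable from compound 2 to compound 3 expected to fall within the scatter. The estimate for compound 3 is 55000 nM, with a range from 20000 nM to 150000 nM, and a fair chance that only a limit is reported.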

Compound 3, half-maximal inhibitory concentration: > 50000 nM
Compound 3 gave a limit, no number (the forecaster's own chance of this, stated with the estimate: 60%); the middle value lies beyond the limit too.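

Neither the 4-bromophenyl of compound 2 nor the 3-bromophenyl of compound 3 yields a number in this assay: compound 3 gives > 50000 nM, which is a limit of the assay and not a number. The step between compound 2 and compound 3 cannot be read, so the two places of the bromine on this ring cannot be ranked against each other. The step of an at least 1.1-fold higher number from compound 1 to compound 3 (0.06 log units; that floor lies within the scatter), with bromo in place of fluoro on an aromatic carbon, adds a second change of this kind whose floor stays within the scatter, and most of the values shown now rest at the same limit: the limit of > 50000 nM in this assay, at which 2 of the 3 values shown sit.

As far as these compounds go, how far compound 2 and compound 3 lie beyond that limit stays open, and so does whether the place of the bromine matters at all. Also open, from the compounds shown here alone, is whether another group on that ring, such as an amine or a carboxylic acid, would bring the value clearly down from the limit and so make changes at this position readable.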